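Pyrrole diesters at the metabotropic glutamate receptor 1

The source may hold more compounds than are shown below. What is called first, only, known or untested is meant among the compounds shown, and "the series" means these compounds.

Measured compounds:
Compound 1, `Cc1c(C(=O)OC(C)C(C)(C)C)c[nH]c1C(=O)Oc1cccnc1`: 720 nM
Compound 2, `CCCOC(=O)c1[nH]c(COC(C)=O)c(C(=O)OC(C)(C)C)c1C`: 2700 nM
Compound 3, `CCCOC(=O)c1[nH]cc(C(=O)OC(C)(C)C)c1C`: 75 nM

In an assay on CHO cells for inhibition of metabotropic glutamate receptor 1 (Rattus norvegicus) (a lower number here means a stronger inhibitor, a higher number a weaker inhibitor), compound 1 gives 720 nM, the second highest of the three numbers. Its nearest neighbour is compound 2 with 2700 nM; furthest away is compound 3 with 75 nM, the lowest number among the three. For the measured compounds named here, the only step between two compounds that differ in one place, a 36-fold lower number from compound 2 to compound 3 (1.56 log units; beyond the scatter), concerns hydrogen in place of acetoxymethyl on an aromatic carbon, a change at a different position from the one considered here.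

Compound 4, `CCN1CCC(OC(=O)c2[nH]cc(C(=O)OC(C)C(C)(C)C)c2C)C1`, differs from compound 1 in one place: 1-ethylpyrrolidin-3-yl in place of pyridin-3-yl on an oxygen next to a carbonyl group. Going by the values given here, no measured step bears on this exchange, and the three compounds on hand do not vary at this position at all, so the direction of the change cannot be read from them. In the absence of any guide, the expectation for compound 4 is a number near that of compound 1, with the expected step of a 1.0-fold lower number from compound 1 to compound 4 (0.01 log units; within the scatter) lying within the scatter. Compound 4 is therefore estimated at 700 nM, with a range from 150 nM to 3500 nM.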

Compound 4, half-maximal inhibitory concentration: 260 nM
Beside the measured number, compound 4's estimate is 2.7-fold (0.43 log units) above it; the range from low to high includes it.
By their numbers in this assay, from the lowest: compound 3; then compound 4; then compound 1; then compound 2.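

The exchange on the oxygen next to a carbonyl group is the first change at this position among the compounds shown, and in this assay it gives a 2.8-fold lower number from compound 1 to compound 4 (0.44 log units; beyond the scatter). The position therefore responds to the group it carries, and the aromatic pyridin-3-yl is not needed to keep this level of inhibition: with a five-membered non-aromatic ring in place of the six-membered aromatic ring, the number falls rather than rises. No accompanying measurement explains the step, so the data do not say which feature of the exchange lies behind it.

Going by these compounds, whether the ring nitrogen of 1-ethylpyrrolidin-3-yl matters stays open, as does the role of its ethyl group; a cyclopentyl group or a 1-methylpyrrolidin-3-yl group on this oxygen would speak to those two questions. On these data alone, it also remains open whether the exchange would give a step of similar size in a compound carrying acetoxymethyl on the core, the group whose replacement by hydrogen gave by far the largest step.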